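The source may hold more compounds than are shown below. What is called first, only, known or untested is meant among the compounds shown, and "the series" means these compounds.

Compound 1 `CCOC(=O)Cc1nc(N)n(C(=O)c2ccccc2)n1`: 38.5%
Compound 2 `CCOC(=O)Cc1nc(N)n(C(=O)c2ccc(Br)cc2)n1`: 43%

Both numbers come from a functional assay on the whole organism (strain albino) for inhibition, with Rattus norvegicus as the target, read by paw edema, with stated times of 30 min and 2 h, at a dose of 5 mg/kg by the oral route; on this read-out higher numbers stand for more inhibition at the one dose given (going by the name of the read-out) and lower numbers for less inhibition. On paper compound 2 stands at the top of the two, but its gap to compound 1 lies within the scatter, so the two cannot be told apart. Compound 3 `CCOC(=O)Cc1nc(N)n(C(=O)c2ccc(OC)cc2)n1` is not yet measured; it differs from compound 2 by methoxy in place of bromo on an aromatic carbon. Among the compounds with values here, the only measured step, a number 4.5 percentage points higher from compound 1 to compound 2 (within the scatter), also concerns a substituent on an aromatic carbon, yet no measured pair exchanges bromo for methoxy. With nothing beyond the scatter among the measured compounds, compound 3 is expected to show a number 3 percentage points lower from compound 2 to compound 3 (within the scatter), a shift not beyond the scatter. Compound 3 is therefore estimated at 40%, likely between 25% and 55%.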

Compound 3, a percentage reported as inhibition, in the whole organism at one dose (the size of the read-out at that dose, not a potency): 41.5%
Compound 3: middle estimate off by 1.5 percentage points, on the low side, and the stated range covers the measured number.
By their numbers in this assay, from the lowest: compounds 1, 3 and 2 (each within the scatter of the next).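

In this assay the change to methoxy gives a number 1.5 percentage points lower from compound 2 to compound 3 (within the scatter) and, set against the unsubstituted ring, a number 3 percentage points higher from compound 1 to compound 3 (within the scatter) at this same place. Hydrogen, bromo and methoxy therefore cannot be told apart here, even though methoxy brings an oxygen and a hydrogen-bond acceptor that the other two lack. No measurement at hand offers an explanation for this flat result. From the compounds shown here alone, whether an amine or a carboxylic acid at this place would shift the number beyond the scatter stays open. So does the effect of any of these groups elsewhere on the ring.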